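Chloro for trifluoromethyl: notes toward compound 3

A few compounds are considered here, and "the series" means these few. Any claim that something is new, unique, unknown or untested is made for them only; others in the source may bear on it.

For the measured compounds named here, compound 2 `CC(C(=O)N1CCN(c2ccccc2C(F)(F)F)CC1)N1C(=O)CCC1=O` stands highest of the two numbers so far: in a functional assay on the whole organism (strain Swiss) with Mus musculus as the target, in the maximal electroshock model, with a stated time of 1 h, at a dose of 300 mg/kg by the intraperitoneal route (a lower number here means a weaker effect, a higher number a stronger effect of the compound at the dose given), compound 2 gives 75%, while compound 1 `CC(C(=O)N1CCN(c2ccc(F)cc2)CC1)N1C(=O)CCC1=O` gives 25%, a gap beyond the scatter. Compound 3 `CC(C(=O)N1CCN(c2ccccc2Cl)CC1)N1C(=O)CCC1=O` is not yet measured. It differs from compound 2 by chloro in place of trifluoromethyl on an aromatic carbon. Going by the values given here, no step between measured compounds isolates this change, so its size is unknown; a moderate drop, possibly no larger than the scatter, is expected, a number 25 percentage points lower from compound 2 to compound 3 (beyond the scatter). For compound 3 the estimated value in this assay is 50%, in the range 25% to 75%.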

Compound 3, a percentage reported as activity, at one dose (the size of the read-out at that dose, not a potency): 25%
Compound 3: middle estimate off by 25 percentage points, on the high side, and the stated range covers the measured number.
By their numbers in this assay, from the lowest: compounds 1 and 3 (each within the scatter of the next); then compound 2.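

In this assay chloro in place of trifluoromethyl on this aromatic carbon, ortho to a large group, gives a number 50 percentage points lower from compound 2 to compound 3 (beyond the scatter) and so the two groups are not interchangeable here. 2-chlorophenyl in place of 4-fluorophenyl on the amine nitrogen in a ring gives no change at the digits printed from compound 1 to compound 3 (within the scatter) and so, among the compounds shown, only the trifluoromethyl compound stands apart. Nothing on hand bears on the reason for either step.

From the compounds shown here alone, whether methyl, methoxy or a nitrile on this carbon would keep the read-out of compound 2 remains open.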